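Swapping the bicyclic group on the urea nitrogen again

The compounds below may be only part of what the source reports. "The series", "measured", "known", "first", "only" and "open" are said of these compounds alone.

Within the data shown here, compound 2 `O=C(Nc1noc2cccnc12)N1CCN(Cc2cccc(Oc3ccc(Cl)cc3)c2)CC1` stands lowest of the two numbers so far: in an assay on isolated protein for inhibition of Fatty-acid amide hydrolase 1 (Rattus norvegicus), with a stated time of 60 min (a lower number here means a stronger inhibitor, a higher number a weaker inhibitor), compound 2 gives 22 nM, while compound 1 `O=C(Nc1cccc2cn[nH]c12)N1CCN(Cc2cccc(Oc3ccc(Cl)cc3)c2)CC1` gives 6000 nM. Compound 3 `O=C(Nc1ccc2nccn2c1)N1CCN(Cc2cccc(Oc3ccc(Cl)cc3)c2)CC1` carries a change at the same place, (a group of 9 heavy atoms (7 carbon, 2 nitrogen; one five-membered aromatic ring with 2 hetero atoms, one six-membered aromatic ring with 1 hetero atom) in place of a group of 9 heavy atoms (6 carbon, 2 nitrogen, 1 oxygen; one five-membered aromatic ring with 2 hetero atoms, one six-membered aromatic ring with 1 hetero atom), on an amide-type nitrogen). Among the measured compounds shown here, only one measured step bears on it: a 270-fold lower number from compound 1 to compound 2 (2.44 log units; beyond the scatter) showed how strongly this assay answers to a swap of the bicyclic group on the amide-type nitrogen. Because that step a 270-fold lower number from compound 1 to compound 2 (2.44 log units; beyond the scatter) was so large, a sizeable move toward a higher number is expected, an 11-fold higher number from compound 2 to compound 3 (1.06 log units; beyond the scatter), giving compound 3 an estimated 250 nM within 30 nM to 2500 nM.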

Compound 3, half-maximal inhibitory concentration: 3600 nM
Estimate against measurement, compound 3: 14-fold (1.16 log units) below; measured number outside the range, above it.
By their numbers in this assay, from the lowest: compound 2; then compounds 3 and 1 (each within the scatter of the next).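

In this assay, a 160-fold higher number from compound 2 to compound 3 (2.21 log units; beyond the scatter) shows that the counted ring types are not enough to keep the low number, since both groups have one five-membered aromatic ring with 2 hetero atoms and one six-membered aromatic ring with 1 hetero atom. By contrast, a 1.7-fold lower number from compound 1 to compound 3 (0.22 log units; within the scatter) places compound 1 and compound 3 at one level despite their different bicyclic groups. Nothing available explains these differences. Going by these compounds, it remains open whether the low number of compound 2 would survive with a single phenyl ring on the amide-type nitrogen.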